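The source may hold more compounds than are shown below. What is called first, only, known or untested is meant among the compounds shown, and "the series" means these compounds.

In a functional assay on HCT-116 cells (Homo sapiens) for antiproliferative activity, read by MTT assay, with a stated time of 48 h (a higher number here means a weaker inhibitor, a lower number a stronger inhibitor), compound 2 `CCCCCCC(CCO)n1cnc2c(N(C)C)ncnc21` gives > 50000 nM, which is a limit of the assay and not a number. Compound 1 `CCCCCCC(CCO)n1cnc2c(NC)ncnc21` gives > 50000 nM, also a limit. Compound 3 `CCCCCCC(CCO)n1cnc2c(N)ncnc21` gives > 50000 nM, again a limit. Compound 2 therefore has no readable potency, and its two relatives share that position: the limit of > 50000 nM in this assay, at which 3 of the 3 values shown sit.

The change leading to compound 4 `CCCCCCCCCCC(CCO)n1cnc2c(N(C)C)ncnc21` lies in the chain rather than in the shared core: butyl in place of hydrogen on a saturated chain carbon, seven bonds along the chain from an aromatic nitrogen. Three measured steps are available. Among the measured compounds shown here, the first is a step that the two limits leave unreadable from compound 1 to compound 2, the second is a step that the two limits leave unreadable from compound 1 to compound 3 and the third is a step that the two limits leave unreadable from compound 2 to compound 3. All three alter only the groups on a nitrogen, so they give no size to carry over to a change in the chain.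

Compound 2 sits at the limit of > 50000 nM, so a readable number could appear only on the stronger side. The expected step, a loose estimate, is an at least 1.6-fold lower number from compound 2 to compound 4 (0.22 log units; that floor lies within the scatter). A further limit would be no surprise. For compound 4 the estimated value is 30000 nM, with an expected range from 8000 nM to 90000 nM.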

Compound 4, half-maximal inhibitory concentration: 5490 nM
Estimate against measurement, compound 4: 5.5-fold (0.74 log units) above, outside the stated range (below it).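

The three steps among compounds 1, 2 and 3 cannot be read, and until compound 4 the series offered no number to compare, only a limit of the assay: the limit of > 50000 nM in this assay, at which 3 of the 4 values shown sit. In this assay, adding butyl in place of hydrogen on a saturated chain carbon, seven bonds along the chain from an aromatic nitrogen, gives an at least 9.1-fold lower number from compound 2 to compound 4 (0.95 log units; beyond the scatter). This makes the chain the first place in the series where a change has a readable effect, and because compound 2 is a limit, the step sets only a floor on its size.

Still open, going by these compounds, is whether a longer chain than that of compound 4 would lower the number further, or whether a carboxylic acid or an amine could take the place of the hydroxyl. It is also unknown whether the groups on the nitrogen would make a readable difference on the longer chain.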